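A Furanylmethyl Arm in Place of Isopropyl on the Amine

This account rests on a few compounds, and the source may have more. Where it says the series, first, only, none or still open, it means among the compounds named here.

Compound 1 `CCCNc1nc(CC)nc2c1cnn2-c1ccccc1` carries a propyl group on the ring nitrogen; in a functional assay on G-361 cells (Homo sapiens) for cytotoxicity, read by sulforhodamine B assay (on this read-out lower numbers stand for stronger inhibition of growth and higher numbers for weaker inhibition of growth), compound 1 gives 37000 nM. Compound 2 `CCc1nc(NC(C)C)c2cnn(-c3ccccc3)c2n1` differs only by isopropyl in place of propyl on that nitrogen. In this assay compound 2 reaches only the assay limit of > 100000 nM, a boundary rather than a number (the limit of > 100000 nM in this assay, at which 1 of the 2 values shown sits). The step of an at least 2.7-fold higher number from compound 1 to compound 2 (0.43 log units; beyond the scatter) thus runs toward weaker growth inhibition. Compound 3 `CCc1nc(NCc2ccco2)c2cnn(-c3ccccc3)c2n1` changes the same position further: (furan-2-yl)methyl in place of isopropyl on a nitrogen on an aromatic ring. Among the measured compounds shown here, only one measured step, an at least 2.7-fold higher number from compound 1 to compound 2 (0.43 log units; beyond the scatter), touches this group, and it exchanged one small alkyl for another, so it bears on the new change only loosely. Compound 3 is therefore expected to sit in the same weak region as its two neighbours, with an estimated step of an at least 1.6-fold lower number from compound 2 to compound 3 (0.22 log units; that floor lies within the scatter) that need not exceed the scatter. Compound 3 is estimated at 60000 nM, within 15000 nM to 150000 nM.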

Compound 3, concentration for total growth inhibition: 32000 nM
Compound 3: the middle estimate sits 1.9-fold (0.27 log units) above what was measured; the range from low to high includes it.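

The step of an at least 3.1-fold lower number from compound 2 to compound 3 (0.49 log units; beyond the scatter) shows that the loss seen with isopropyl on this nitrogen does not extend to every larger group, since the (furan-2-yl)methyl arm restores measurable growth inhibition. The step of a 1.2-fold lower number from compound 1 to compound 3 (0.06 log units; within the scatter) places this ring-bearing arm level with the straight propyl group, so among these three compounds only the branched isopropyl stands apart. The true size of the first step stays unknown, and compound 2 stands at a limit, not a number: the limit of > 100000 nM in this assay, at which 1 of the 3 values shown sits.

The compounds shown leave open whether the furan ring itself matters, or whether a benzyl or thiophen-2-ylmethyl arm would serve equally well. They also leave open whether a longer chain or a cyclopropylmethyl group on this nitrogen would move the read-out beyond this level.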